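Imidazopyrazine series: aryl group swap from bromo to methoxy

A few compounds are considered here, and "the series" means these few. Any claim that something is new, unique, unknown or untested is made for them only; others in the source may bear on it.

Measured so far:
compound 1 `COc1ccc(-c2cn3ccnc3c(-c3ccc4ncn(C5CCCCC5)c4c3)n2)cc1` gives 97.4% in a functional assay on MDA-MB-468 cells (Homo sapiens) for inhibition, read by sulforhodamine B assay, with a stated time of 48 h, tested at 10 uM; a higher number here means more inhibition at the concentration tested (going by the name of the read-out), a lower number less inhibition
compound 2 `Clc1ccc(-c2cn3ccnc3c(-c3ccc4ncn(C5CCCCC5)c4c3)n2)cc1` gives 10.6%
compound 3 `Brc1ccc(-c2cn3ccnc3c(-c3ccc4ncn(C5CCCCC5)c4c3)n2)cc1` gives 33.7%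

Compound 3 stands second highest of the three in this assay, with compound 2 lower by a number 23.1 percentage points higher from compound 2 to compound 3 (beyond the scatter) and compound 1 higher by a number 63.7 percentage points lower from compound 1 to compound 3 (beyond the scatter). Compound 4 `COc1ccccc1-c1cn2ccnc2c(-c2ccc3ncn(C4CCCCC4)c3c2)n1` is not yet measured; the change is 2-methoxyphenyl in place of 4-bromophenyl on an aromatic carbon. The bearing steps are the loss of methoxy, a number 86.8 percentage points lower from compound 1 to compound 2 (beyond the scatter) and a number 63.7 percentage points lower from compound 1 to compound 3 (beyond the scatter), both large. Going by the values given here, compound 4 regains a methoxy group, so a large rise is expected, though its new placement has no precedent among the measured compounds, which widens the range. The expected step is a number 36.3 percentage points higher from compound 3 to compound 4 (beyond the scatter). Compound 4 is estimated at 70%, between 30% and 97%.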

Compound 4, a percentage reported as inhibition, at one concentration (the size of the read-out at that concentration, not a potency): 14.6%
Beside the measured number, compound 4's estimate is 55.4 percentage points above it, and the stated range ends above it.
By their numbers in this assay, from the lowest: compounds 2 and 4 (each within the scatter of the next); then compound 3; then compound 1.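

A methoxy group alone does not carry the inhibition in this assay: 2-methoxyphenyl in place of 4-methoxyphenyl gives a number 82.8 percentage points lower from compound 1 to compound 4 (beyond the scatter), so in this pair the placement of the methoxy decides the read-out. Against the halogen analogues, 2-methoxyphenyl gives a number 19.1 percentage points lower from compound 3 to compound 4 (beyond the scatter) and a number 4 percentage points higher from compound 2 to compound 4 (within the scatter), leaving compound 1 alone at the top of the four. No measured evidence explains this difference.

From the compounds shown here alone, an ethoxy or amino group in place of the methoxy of compound 1 remains open, so how specific the 4-methoxyphenyl result is cannot yet be judged.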